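Cytotoxicity notes on a diarylmethylamine series

A few compounds are considered here, and "the series" means these few. Any claim that something is new, unique, unknown or untested is made for them only; others in the source may bear on it.

Measured so far in an ADME assay on MT4 cells (Homo sapiens) for cytotoxicity, read by MTT assay, with a stated time of 5 days; on this read-out lower numbers stand for higher toxicity in this test and higher numbers for lower toxicity in this test:

Compound 1, `CC(O)CNC(c1ccc(C#N)cc1)c1ccnc(Nc2ccc(C#N)cc2)n1`: compound 1 gives > 65000 nM, which is a limit of the assay and not a number.
Compound 2, `CNC(c1ccc(C#N)cc1)c1ccnc(Nc2ccc(C#N)cc2)n1`: compound 2 gives 189000 nM.

Compound 1 thus stands at a limit in this assay, with no number of its own. For the measured compounds named here, the one measured step, a step that the limit leaves unreadable from compound 1 to compound 2, cannot be read because of the limit of > 65000 nM in this assay, at which 1 of the 2 values shown sits, so the series gives no readable step at all.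

Compound 3, `CC(O)CNC(c1ccnc(Nc2ccc(C#N)cc2)n1)c1ccccc1Cl`, differs from compound 1 by 2-chlorophenyl in place of 4-cyanophenyl on a saturated chain carbon bound to an amine nitrogen and an aromatic carbon. Going by the values given here, no measured step bears on this change: the only step recorded concerns the chain on the amine nitrogen, not the aromatic ring on the saturated chain carbon. Compound 2, with a number rather than a limit, shows that the series can sit well within the measured range, and nothing measured points to a change beyond the usual scatter. Compound 3 is therefore expected to lie near the limit at which compound 1 stands, with a step that the limit leaves unreadable from compound 1 to compound 3 read as no step beyond the scatter. The estimate for compound 3 is 100000 nM, within 40000 nM to 250000 nM.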

Compound 3, half-maximal cytotoxic concentration: 34700 nM
Compound 3: the middle estimate sits 2.9-fold (0.46 log units) above what was measured, outside the stated range (below it).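

In this assay, for the compounds shown here, 2-chlorophenyl in place of 4-cyanophenyl on a saturated chain carbon bound to an amine nitrogen and an aromatic carbon gives an at least 1.8-fold lower number from compound 1 to compound 3 (0.27 log units; that floor lies within the scatter), the first step that can be read at all and the first to concern this place rather than the chain on the amine nitrogen. The chain of compound 1 stays in place in compound 3. Compound 3 gives 34700 nM, a number rather than a limit. The printed floor of the step lies within the scatter, so a change beyond the scatter is not established. Compound 1 gives only a limit, and the full size of the step stays open because of it: the limit of > 65000 nM in this assay, at which 1 of the 3 values shown sits.

A plain phenyl on this carbon, carrying neither chlorine nor nitrile, would show whether the lower number goes with the arrival of 2-chlorophenyl or the departure of 4-cyanophenyl. Also open, as far as these compounds go, is how 2-chlorophenyl reads when paired with the chain of compound 2, and how an amine or a carboxylic acid on this ring would read.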